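Replacing the ring on the sulfur-bound carbon of compound 3

The compounds below may be only part of what the source reports. "The series", "measured", "known", "first", "only" and "open" are said of these compounds alone.

Compound 1 `C[C@]1(O)CC(=O)OC(CSc2nc(-c3ccccc3)c(-c3ccccc3)[nH]2)C1`: 140 nM
Compound 2 `CO[C@H]1C[C@H](O)C[C@@H](CSc2nc(-c3ccccc3)c(-c3ccccc3)[nH]2)O1`: 90 nM
Compound 3 `O=C1CC(O)CC(CSc2nc(-c3ccccc3)c(-c3ccccc3)[nH]2)O1`: 910 nM

In an assay on microsomes from liver for inhibition of sterol O-acyltransferase 1 (Rattus norvegicus) (on this read-out higher numbers stand for weaker inhibition and lower numbers for stronger inhibition), compound 3 gives the highest of the three numbers. The step of a 6.5-fold higher number from compound 1 to compound 3 (0.81 log units; beyond the scatter) and the step of a 10-fold higher number from compound 2 to compound 3 (1.00 log units; beyond the scatter) both lie beyond the scatter, while a 1.6-fold lower number from compound 1 to compound 2 (0.19 log units; within the scatter) does not. Compound 4 `c1ccc(-c2nc(SCC3OCCCO3)[nH]c2-c2ccccc2)cc1` carries the change (a group of 6 heavy atoms (4 carbon, 2 oxygen; one six-membered non-aromatic ring with 2 hetero atoms) in place of a group of 8 heavy atoms (5 carbon, 3 oxygen; one six-membered non-aromatic ring with 1 hetero atom), on a saturated chain carbon bound to a sulfur). Among the measured compounds shown here, no measured step involves such a ring, but the two steps into compound 3 show that this position moves the number substantially, so a shift beyond the scatter is plausible in either direction. The estimate for compound 4 is therefore 400 nM (range 80 nM to 2000 nM), corresponding to an expected 2.3-fold lower number from compound 3 to compound 4 (0.36 log units; beyond the scatter).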

Compound 4, half-maximal inhibitory concentration: 180 nM
For compound 4 the middle estimate is 2.2-fold (0.35 log units) above the measured one; low and high end bracket the measured number.
By their numbers in this assay, from the lowest: compounds 2, 1 and 4 (each within the scatter of the next); then compound 3.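

In this assay, the change to the ring with 2 hetero atoms gives a 5.1-fold lower number from compound 3 to compound 4 (0.70 log units; beyond the scatter), so a group with 0 hydrogen-bond donors and no double bond outside aromatic rings still holds a low number at this position. The steps of a 2.0-fold higher number from compound 2 to compound 4 (0.30 log units; within the scatter) and a 1.3-fold higher number from compound 1 to compound 4 (0.11 log units; within the scatter) lie within the scatter, so these three compounds cannot be ordered. No available evidence bears on what lies behind this shift. The compounds shown leave open how an amine, a carboxylic acid or an open chain without a ring would read on the saturated chain carbon bound to a sulfur.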